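A few compounds are considered here, and "the series" means these few. Any claim that something is new, unique, unknown or untested is made for them only; others in the source may bear on it.

Measured in a functional assay on NCI-H661 cells (Homo sapiens) for inhibition, read by MTT assay, with a stated time of 72 h; on this read-out lower numbers stand for stronger inhibition and higher numbers for weaker inhibition:
Compound 1 `O=C(NO)c1ccc(CNCc2nc(-c3ccccc3)no2)cc1`: > 100000 nM, a limit
Compound 2 `O=C(NO)c1ccc(CNCc2nc(-c3ccc([N+](=O)[O-])cc3)no2)cc1`: > 100000 nM, a limit
Compound 3 `O=C(NO)c1ccc(CNCc2nc(-c3ccc(F)cc3)no2)cc1`: > 100000 nM, a limit

Compound 3 stands only at a limit, > 100000 nM, and gives no number. The whole series shares this position: the limit of > 100000 nM in this assay, at which 3 of the 3 values shown sit.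

Compound 4 `O=C(NO)c1ccc(CNCc2nc(-c3cccs3)no2)cc1` differs from compound 3 by thiophen-2-yl in place of 4-fluorophenyl on an aromatic carbon, with thiophen-2-yl in place of 4-fluorophenyl on an aromatic carbon. Going by the values given here, three measured steps bear on this change: a step that the two limits leave unreadable from compound 1 to compound 2, a step that the two limits leave unreadable from compound 1 to compound 3 and a step that the two limits leave unreadable from compound 2 to compound 3. None has a readable size, and none replaces the whole ring. Among the compounds with values here, no step of known size or direction can therefore be expected in this assay, and the same limit seems the likeliest outcome. The expected change is a number no higher from compound 3 to compound 4 (the limit leaves the size open). For compound 4 the estimated value is 100000 nM, with an expected range of 30000 nM to 300000 nM.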

Compound 4, half-maximal inhibitory concentration: > 100000 nM
Compound 4: no number, only a limit; the forecaster's own chance of this, stated with the estimate: 75%; the middle value lies on the limit itself.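

Going by these compounds alone, compound 4 also gives only a limit, and no step to it from compound 1, compound 2 or compound 3 can be read. The compounds shown leave open what number any of these four would give in this assay.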